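Cytotoxicity notes on the shared core: aryl substituent exchange

The source may report more compounds than this note shows. Statements on the series, on what has been measured and on what is new or still open speak of the compounds shown alone.

compound 1 `C=Cc1cccc(-c2[nH]c3cc(OC)ccc3c(=O)c2C(=O)OCC)c1`: > 21500 nM
compound 2 `CCOC(=O)c1c(-c2cccc(OC)c2)[nH]c2cc(OC)ccc2c1=O`: > 21500 nM
compound 3 `CCOC(=O)c1c(-c2cccc(OC(F)(F)F)c2)[nH]c2cc(OC)ccc2c1=O`: > 21500 nM

In an ADME assay on BJ cells (Homo sapiens) for cytotoxicity, read by luminescence, with a stated time of 72 h (on this read-out lower numbers stand for an effect already at smaller amounts and higher numbers for an effect only at larger amounts of compound), compound 1 reports only a limit, > 21500 nM. Compound 2 likewise reports a limit, > 21500 nM. Compound 3 also reports a limit, > 21500 nM. All three sit at the limit of > 21500 nM in this assay, at which 3 of the 3 values shown sit, so compound 1 cannot be ranked against the others; the steps a step that the two limits leave unreadable from compound 1 to compound 2, a step that the two limits leave unreadable from compound 1 to compound 3 and a step that the two limits leave unreadable from compound 2 to compound 3 have no readable size.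

Compound 4 `CCOC(=O)c1c(-c2cccc(N(C)C)c2)[nH]c2cc(OC)ccc2c1=O` carries the change dimethylamino in place of vinyl on an aromatic carbon relative to compound 1. The two measured steps out of compound 1 exchange the same vinyl group and both remain at the limit, so no step beyond the scatter is expected here either. Compound 4 is therefore expected to report another limit, estimated at 30000 nM with a range of 15000 nM to 100000 nM, which means an expected step that the limit leaves unreadable from compound 1 to compound 4.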

Compound 4, half-maximal effective concentration: > 21500 nM
Compound 4: only a limit was reported (the forecaster's own chance of this, stated with the estimate: 85%); the middle value does not contradict the limit.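

No new step can be read in this assay between compound 4 and compound 1, compound 2 or compound 3, as each reports only a limit: the limit of > 21500 nM in this assay, at which 4 of the 4 values shown sit.

The compounds shown leave open whether any substituent exchange on the shared core produces a measurable cytotoxic effect in this assay.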